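The source may hold more compounds than are shown below. What is called first, only, known or untested is meant among the compounds shown, and "the series" means these compounds.

Working notes on the series. In an assay on HT-29 cells for inhibition of Serine-protein kinase ATM (Homo sapiens), read by fluorescence, with a stated time of 1 h (a higher number here means a weaker inhibitor, a lower number a stronger inhibitor), compound 3 `CCC(CC)CNc1c(C(N)=O)cnc2ccc(-c3ccc(COC)nc3)cc12` gives 45 nM, the lowest of the three numbers in hand, although all three lie within the scatter of one another. Compound 2 `CCC(CC)CNc1c(C(N)=O)cnc2ccc(-c3ccc(C)nc3)cc12` gives 50 nM in this assay, and compound 1 `CCC(CC)CNc1c(C(N)=O)cnc2ccc(-c3cccnc3)cc12` gives 73 nM. Among the compounds with values here, the measured steps of a 1.5-fold lower number from compound 1 to compound 2 (0.16 log units; within the scatter), a 1.6-fold lower number from compound 1 to compound 3 (0.21 log units; within the scatter) and a 1.1-fold lower number from compound 2 to compound 3 (0.05 log units; within the scatter) are all within the scatter, so nothing measured so far moves the read-out beyond noise.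

Compound 4 `CCC(CC)CNc1c(C(N)=O)cnc2ccc(-c3ccc(CS(C)(=O)=O)nc3)cc12` differs from compound 3 by methylsulfonyl in place of methoxy on a saturated chain carbon bound to an aromatic carbon. Within the data shown here, the only measured step at the same place, a 1.1-fold lower number from compound 2 to compound 3 (0.05 log units; within the scatter), was within the scatter, as was the related step of a 1.6-fold lower number from compound 1 to compound 3 (0.21 log units; within the scatter) one bond further out; no measured step swaps one group for another at this carbon, so a methylsulfonyl here has no precedent. On that basis no step beyond the scatter is expected in this assay in either direction. Compound 4 is therefore estimated at 50 nM with a range of 20 nM to 130 nM. The expected step of a 1.1-fold higher number from compound 3 to compound 4 (0.05 log units; within the scatter) stays within the scatter.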

Compound 4, half-maximal inhibitory concentration: 39 nM
Compound 4: middle estimate off by 1.3-fold (0.11 log units), on the high side; measured number inside the range.
By their numbers in this assay, from the lowest: compounds 4, 3, 2 and 1 (each within the scatter of the next).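

In this assay, within the data shown here, methylsulfonyl in place of methoxy on a saturated chain carbon bound to an aromatic carbon gives a 1.2-fold lower number from compound 3 to compound 4 (0.06 log units; within the scatter), the first exchange of one group for another at this carbon, and that step lies within the scatter. Methylsulfonyl in place of hydrogen at the same carbon gives a 1.3-fold lower number from compound 2 to compound 4 (0.11 log units; within the scatter), and (methylsulfonyl)methyl in place of hydrogen on an aromatic carbon gives a 1.9-fold lower number from compound 1 to compound 4 (0.27 log units; within the scatter), so neither the full change nor its parts move the read-out beyond the scatter. Nothing in hand explains this result.

From the compounds shown here alone, what an amine or a carboxylic acid at this carbon would do to the read-out stays open, as does whether any group here can move it beyond the scatter. Going by these compounds, the role of the rest of the molecule also stays open, since all four compounds share everything outside this substituent.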